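The compounds below may be only part of what the source reports. "The series", "measured", "known", "first", "only" and "open" are said of these compounds alone.

Compounds measured in a functional assay on CHO cells for inhibition of metabotropic glutamate receptor 5 (Rattus norvegicus), read by FLIPR and calcium flux; on this read-out higher numbers stand for weaker inhibition and lower numbers for stronger inhibition:
compound 1, `Cc1ccc2ccc(-c3cccc(C#N)c3)cc2n1`, which gives 7.7 nM
compound 2, `COCc1cccc(-c2ccc3ccc(C)nc3c2)c1`, which gives 5800 nM
compound 3, `Cc1ccc2ccc(-c3cccc(OC(F)(F)F)c3)cc2n1`; for compound 3 the assay reports only a limit, > 10000 nM

Compound 1 has the lowest number of the values that are actual numbers; its nearest neighbour is compound 2, and the step of a 750-fold higher number from compound 1 to compound 2 (2.88 log units; beyond the scatter) lies well beyond the scatter. Compound 3 sits at the limit of > 10000 nM in this assay, at which 1 of the 3 values shown sits, so the step of an at least 1200-fold higher number from compound 1 to compound 3 (3.11 log units; beyond the scatter) is known only as a floor. Both steps away from compound 1 replace its cyano group, and both cost a great deal of potency.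

The unmeasured compound 4, `COc1cc(C#N)cc(-c2ccc3ccc(C)nc3c2)c1`, differs from compound 1 in a different way: methoxy in place of hydrogen on an aromatic carbon. The cyano group stays in place. Among the measured compounds shown here, no measured step adds a group while keeping the cyano, so the two large steps from compound 1 bear on compound 4 only in showing that the cyano itself carries much of the potency; they do not say how an added methoxy is tolerated. Compound 4 is therefore expected to stay close to compound 1, with at most a modest rise in this assay, giving a 2.6-fold higher number from compound 1 to compound 4 (0.41 log units; beyond the scatter). The estimate for compound 4 is 20 nM, within 5 nM to 120 nM.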

Compound 4, half-maximal inhibitory concentration: 2.4 nM
Estimate against measurement, compound 4: 8.3-fold (0.92 log units) above; the measured number lies below the stated range.
By their numbers in this assay, from the lowest: compound 4; then compound 1; then compound 2. At a limit, above all of these: compound 3.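

In this assay, the carbon meta to a cyano group and meta to a large group takes a methoxy in place of hydrogen, and the number falls, a change that lies beyond the scatter (a 3.2-fold lower number from compound 1 to compound 4 (0.51 log units; beyond the scatter)). The earlier steps shown here all replaced the cyano group and showed only large rises, so they said nothing about a second site on the same ring; this step shows that with the cyano group kept, this carbon is open to substitution and that the added methoxy brings a modest gain rather than a loss. None of the information at hand gives a reason for this gain.

The compounds shown leave open whether the gain is particular to methoxy, or whether a fluorine, a hydroxyl, an ethoxy or a longer chain such as a propoxy on the same carbon would give a similar number. They also leave open whether a methoxy on this carbon would help at all once the cyano group is replaced by methoxymethyl or trifluoromethoxy, or whether its gain holds only alongside the cyano group.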